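The source may report more compounds than this note shows. Statements on the series, on what has been measured and on what is new or still open speak of the compounds shown alone.

Compound 1 `COc1ccc(N)c(C(=O)CCNC(=O)C2CC2)c1` was tested in an assay for inhibition of Nitric oxide synthase, inducible (Homo sapiens), read by scintillation counting, with a stated time of 30 min, tested at 1 mM (on this read-out lower numbers stand for less inhibition and higher numbers for more inhibition at the one concentration tested (going by the name of the read-out)), and gave 2.66%. Compound 2 `Nc1ccc(Cl)cc1C(=O)CCNC(=O)C1CC1` gave 5.37% in this assay; the change between them, chloro in place of methoxy on an aromatic carbon, produced a step of a number 2.7 percentage points higher from compound 1 to compound 2 (within the scatter). Compound 3 `CNC(=S)NCCC(O)c1cc(OC)ccc1N` has a different core, and the difference between the two cores is not broken down here; in this assay compound 3 gave 76.6%. Compound 4 `CNC(=S)NCCC(O)c1cc(Cl)ccc1N` is derived from compound 3 by the same kind of change (chloro in place of methoxy on an aromatic carbon), here meta to a group of 9 heavy atoms rather than meta to a large group. Because a number 2.7 percentage points higher from compound 1 to compound 2 (within the scatter) stayed within the scatter, a similarly small step is expected, a number 6.6 percentage points lower from compound 3 to compound 4 (within the scatter). Compound 4 is therefore estimated at 70%, between 45% and 88%.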

Compound 4, a percentage reported as inhibition, at one concentration (the size of the read-out at that concentration, not a potency): 22.1%
Compound 4: the middle estimate sits 47.9 percentage points above what was measured; measured number outside the range, below it.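

The same change did not carry over from one core to the other in this assay: the same change on two cores in this assay, a number 2.7 percentage points higher (within the scatter) from compound 1 to compound 2 and a number 54.5 percentage points lower (beyond the scatter) from compound 3 to compound 4, 57.2 percentage points apart, beyond the scatter of two such steps. On the core of compound 3 the exchange of methoxy for chloro gave a number 54.5 percentage points lower from compound 3 to compound 4 (beyond the scatter), so a small step on one core did not predict the step on the other in this series. The two pairs show only that the outcome depends on the core; the cores differ in more than one place, and these compounds do not tell which part of them matters.

Going by these compounds, it remains open how other groups on that aromatic carbon, such as fluoro, methyl or ethoxy, would fare on the core of compound 3. On these data alone, it is also open whether a second pair on either core would repeat what these two pairs show.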